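Working notes: from compound 2 to compound 4

The source may report more compounds than this note shows. Statements on the series, on what has been measured and on what is new or still open speak of the compounds shown alone.

Measured so far:
compound 1 `CCOC(=O)C(C)Oc1ccc(NC(=O)CSc2ccc3ccccc3c2)cc1`: 28%
compound 2 `CCOC(=O)C(C)Oc1ccc(NC(=O)COc2ccccc2C(C)CC)cc1`: 25%
compound 3 `CCOC(=O)CCCOc1ccc(NC(=O)COc2ccc3ccccc3c2)cc1`: 25%

In a functional assay for inhibition, read by spectrophotometry, tested at 200 ug/mL (a lower number here means less inhibition, a higher number more inhibition at the concentration tested (going by the name of the read-out)), compound 1 gives 28%, compound 2 gives 25% and compound 3 gives 25%. Compound 2 and compound 3 read the same at the digits shown, and the number for compound 1 lies within the scatter of both, so the three cannot be ranked in this assay; all three sit in one narrow band. No pair of these compounds differs in only one place, so no measured step is available to guide the next one.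

Compound 4 `CCOC(=O)C(C)Oc1ccc(NC(=O)COc2ccccc2Cl)cc1` differs from compound 2 in one place: chloro in place of sec-butyl on an aromatic carbon. Nothing in the measured set speaks to this particular exchange. Given how closely the three measured numbers sit, the step of no change at the digits printed from compound 2 to compound 4 (within the scatter) in this assay is expected to stay within the scatter, in no set direction. For compound 4 the estimated value in this assay is 25%, with a range from 12% to 40%.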

Compound 4, a percentage reported as inhibition, at one concentration (the size of the read-out at that concentration, not a potency): 26%
Compound 4: the middle estimate sits 1 percentage points below what was measured, and the stated range covers the measured number.
By their numbers in this assay, from the lowest: compounds 2, 3, 4 and 1 (each within the scatter of the next).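

In this assay, the series now has a one-place step to read: chloro in place of sec-butyl on an aromatic carbon, ortho to a large group, gives a number 1 percentage points higher from compound 2 to compound 4 (within the scatter). At this place, then, a group of 4 heavy atoms and a group of 1 heavy atom cannot be told apart in this read-out, so this exchange gives no handle on the number. No separate measurement bears on why the two compounds read alike.

On these data alone, whether an amine, a carboxylic acid or a longer chain on this same aromatic carbon would move the number beyond the scatter remains open. Also open, as far as these compounds go, is whether this exchange would read the same with the other ester and thioether variations seen.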